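The source may report more compounds than this note shows. Statements on the series, on what has been measured and on what is new or still open speak of the compounds shown alone.

In an in vitro functional assay on cells for antagonist activity at B1 bradykinin receptor (Homo sapiens), read by luminescence and calcium flux, with a stated time of 2 h (on this read-out higher numbers stand for weaker inhibition and lower numbers for stronger inhibition), compound 1 `Cc1cc(S(=O)(=O)N2C=CNC(=O)[C@H]2CC(=O)N[C@H]2CCN(C)CC2(C)C)c(C)cc1Cl` gives 0.28 nM. In this assay compound 2 `Cc1cc(S(=O)(=O)N2C=CNC(=O)[C@H]2CC(=O)N2CC[C@H](N3CCCC3)C2)c(C)cc1Cl` gives 19 nM. In this assay compound 3 `Cc1cc(S(=O)(=O)N2C=CNC(=O)[C@H]2CC(=O)N2CCCC(N(C)C)CC2)c(C)cc1Cl` gives 2.7 nM.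

Among these three, compound 3 stands second highest: a 9.6-fold higher number from compound 1 to compound 3 (0.98 log units; beyond the scatter), while a 7.0-fold lower number from compound 2 to compound 3 (0.85 log units; beyond the scatter). Compound 4 `Cc1cc(S(=O)(=O)N2C=CNC(=O)[C@H]2CC(=O)N2CCCCC(N(C)C)CC2)c(C)cc1Cl` carries one further change: a group of 11 heavy atoms (9 carbon, 2 nitrogen; one eight-membered non-aromatic ring with 1 hetero atom) in place of a group of 10 heavy atoms (8 carbon, 2 nitrogen; one seven-membered non-aromatic ring with 1 hetero atom), on a carbonyl carbon. The step that bears on it most directly is the earlier widening of the same ring, a 9.6-fold higher number from compound 1 to compound 3 (0.98 log units; beyond the scatter), a modest loss in this assay; the wider gap a 68-fold higher number from compound 1 to compound 2 (1.83 log units; beyond the scatter) involved a different rearrangement and bears less. One more ring atom is therefore expected to raise the number again by a modest amount, a 3.0-fold higher number from compound 3 to compound 4 (0.47 log units; beyond the scatter). Compound 4 is estimated at 8 nM, with a likely range from 2.5 nM to 30 nM.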

Compound 4, half-maximal inhibitory concentration: 4.75 nM
Compound 4: middle estimate off by 1.7-fold (0.23 log units), on the high side, within the range that was stated.
By their numbers in this assay, from the lowest: compound 1; then compounds 3 and 4 (each within the scatter of the next); then compound 2.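

Widening the seven-membered ring to the eight-membered ring makes no clear difference in this assay, with a 1.8-fold higher number from compound 3 to compound 4 (0.25 log units; within the scatter). The gap to the six-membered ring remains, with a 17-fold higher number from compound 1 to compound 4 (1.23 log units; beyond the scatter), while the eight-membered ring reads better than the two five-membered rings, with a 4.0-fold lower number from compound 2 to compound 4 (0.60 log units; beyond the scatter). Nothing available explains these differences. Still open, as far as these compounds go, is how a primary amine or a carboxylic acid would read on the eight-membered ring. Also open, from the compounds shown here alone, is whether a still larger ring would stay at this level.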